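Replacing Methylsulfanyl with Pyridin-2-yl on the Shared Core

The source may report more compounds than this note shows. Statements on the series, on what has been measured and on what is new or still open speak of the compounds shown alone.

Three compounds have been measured in a functional assay on SUP-T1 cells (Homo sapiens) for antiproliferative activity; a higher number here means a weaker inhibitor, a lower number a stronger inhibitor:

compound 1 `CSc1nc2c([nH]1)C(=O)C(Br)=C(Br)C2=O`: 6.26 uM
compound 2 `CSc1nc2c([nH]1)C(=O)C=C(Br)C2=O`: 5.03 uM
compound 3 `COC1=CC(=O)c2[nH]c(SC)nc2C1=O`: 5.07 uM

Compound 2 has the lowest of the three numbers, but this means little: the step of a 1.2-fold lower number from compound 1 to compound 2 (0.10 log units; within the scatter) and the step of a 1.0-fold higher number from compound 2 to compound 3 (0.00 log units; within the scatter) both stay within the scatter, so the three compounds cannot be told apart on these data.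

Compound 4 `O=C1C(Br)=CC(=O)c2[nH]c(-c3ccccn3)nc21` is not yet measured. It differs from compound 2 in one place: pyridin-2-yl in place of methylsulfanyl on an aromatic carbon. Neither measured step bears on this change. Both of them, from compound 1 to compound 2 and from compound 2 to compound 3, concern the double-bonded ring carbon, and both were flat. Going by the values given here, the aromatic carbon between the two ring nitrogen atoms has not been varied at all, so there is no measured step from which the size or direction of this change could be read.

With the three measured numbers all close together and no guidance for this position, compound 4 is expected to give 5 uM, within 1.2 uM to 20 uM, which is an estimated step of a 1.0-fold lower number from compound 2 to compound 4 (0.00 log units; within the scatter) that is wide on both sides.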

Compound 4, concentration for 50% inhibition: 5.57 uM
For compound 4 the middle estimate is 1.1-fold (0.05 log units) below the measured one; measured number inside the range.
By their numbers in this assay, from the lowest: compounds 2, 3, 4 and 1 (each within the scatter of the next).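

This is the first change shown at the aromatic carbon between two ring nitrogen atoms, and in this assay the exchange of methylsulfanyl for pyridin-2-yl gives a 1.1-fold higher number from compound 2 to compound 4 (0.04 log units; within the scatter). Going by these compounds alone, a six-membered aromatic ring can therefore enter at this place, where the earlier compounds carried only methylsulfanyl, without a change in the number that can be told from the scatter. The flat picture seen so far on the double-bonded ring carbon thus also holds for this one exchange at a second place on the shared core, although no information is available on why the number stays the same here.

As far as these compounds go, it remains open whether this aromatic carbon responds to any group at all, since a primary amine, a carboxylic acid or a longer alkyl chain in the same place could still move the number beyond the scatter. It is equally open whether pyridin-2-yl would behave the same way with hydrogen or methoxy in place of bromo on the double-bonded ring carbon, as the compounds shown pair it with bromo alone.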